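The source may hold more compounds than are shown below. What is called first, only, known or untested is meant among the compounds shown, and "the series" means these compounds.

The measured compounds in a functional assay on SSMC-7721 cells (Homo sapiens) for antiproliferative activity, read by CCK-8 assay, with a stated time of 48 h; a lower number here means a stronger inhibitor, a higher number a weaker inhibitor:
compound 1 `O=c1c2ccccc2[se]n1-c1nnc(-c2ccc(Br)cc2)s1`, 68200 nM;
compound 2 `O=c1c2ccccc2[se]n1-c1nnc(-c2cccc([N+](=O)[O-])c2)s1`, 27300 nM;
compound 3 `COc1cc(-c2nnc(-n3[se]c4ccccc4c3=O)s2)cc(OC)c1OC`, 7150 nM.

Compound 1 has the highest number of the three. Its nearest neighbour is compound 2, whose number is lower by a margin beyond the scatter, and compound 3 stands furthest away, also beyond the scatter. Compound 4 `O=c1c2ccccc2[se]n1-c1nnc(-c2ccc(Cl)cc2)s1` has not been measured in this assay. It differs from compound 1 in one place: chloro in place of bromo on an aromatic carbon, on an aromatic carbon of a six-membered aromatic ring of carbon only, para to a large group. For the measured compounds named here, no measured pair shows this exchange, so only the number of compound 1, 68200 nM, offers a starting point. Exchanging one halogen for another is expected to move the number little, within the scatter. Compound 4 is therefore estimated at 75000 nM, between 30000 nM and 190000 nM. The expected step is a 1.1-fold higher number from compound 1 to compound 4 (0.04 log units; within the scatter), no larger than the scatter.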

Compound 4, half-maximal inhibitory concentration: 24400 nM
Compound 4: middle estimate off by 3.1-fold (0.49 log units), on the high side; measured number outside the range, below it.
By their numbers in this assay, from the lowest: compound 3; then compounds 4 and 2 (each within the scatter of the next); then compound 1.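

Chloro in place of bromo gives a 2.8-fold lower number from compound 1 to compound 4 (0.45 log units; beyond the scatter) in this assay, so at this place, para to a large group, even an exchange of one halogen for another changes the number. For the compounds shown here, the earlier compounds offered no pair differing in one place, so this is the first single change that can be read here. Nothing measured accounts for the step. From the compounds shown here alone, whether fluoro, iodo or an amine at this place would give a lower or a higher number remains open, as does whether the same exchange would give a similar step on another carbon of the ring.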